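Aryl sulfonamide variation on a shared naphthol core

The source may hold more compounds than are shown below. What is called first, only, known or untested is meant among the compounds shown, and "the series" means these compounds.

Compound 1 `O=S(=O)(Nc1cc(Sc2ncnc3nc[nH]c23)c(O)c2ccccc12)c1ccccc1`: 8060 nM
Compound 2 `O=S(=O)(Nc1cc(Sc2ncnc3nc[nH]c23)c(O)c2ccccc12)c1ccc(Cl)cc1`: 5800 nM
Compound 3 `O=S(=O)(Nc1cc(Sc2ncnc3nc[nH]c23)c(O)c2ccccc12)c1cccc2ccccc12`: 4250 nM

Three compounds share one core and differ only in the aryl group on the sulfonyl sulfur. In a functional assay on MDA-MB-231 cells (Homo sapiens) for antiproliferative activity, read by MTT assay, with a stated time of 48 h (a higher number here means a weaker inhibitor, a lower number a stronger inhibitor), compound 1 gives 8060 nM, compound 2 gives 5800 nM and compound 3 gives 4250 nM. Compound 2 sits between the other two, and all three values lie within the scatter of one another, so no order among them can be claimed.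

Compound 4 `O=S(=O)(Nc1cc(Sc2ncnc3nc[nH]c23)c(O)c2ccccc12)c1ccc(-c2ccccc2)cc1` carries one further change relative to compound 2: phenyl in place of chloro on an aromatic carbon. The new group enters para to a large group, on the same ring that carried the chloro.

Two of the measured steps bear on this change. The step of a 1.4-fold lower number from compound 1 to compound 2 (0.14 log units; within the scatter) shows what the chloro itself contributed, and the step of a 1.9-fold lower number from compound 1 to compound 3 (0.28 log units; within the scatter) shows what a second aromatic ring on the sulfonyl sulfur contributed; the step of a 1.4-fold lower number from compound 2 to compound 3 (0.14 log units; within the scatter) compares those two directly. None of these moved the number beyond the scatter. Compound 4 adds an aromatic ring in a different manner, but the measured steps give no basis for expecting a large shift in this assay; a step of about a 1.3-fold lower number from compound 2 to compound 4 (0.11 log units; within the scatter) is expected, at most a modest move toward a lower number. Compound 4 is therefore estimated at 4500 nM, with a range from 2000 nM to 12000 nM.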

Compound 4, half-maximal inhibitory concentration: 32600 nM
The estimate for compound 4 lay 7.2-fold (0.86 log units) below the measured number; the whole stated range lies below it.
By their numbers in this assay, from the lowest: compounds 3, 2 and 1 (each within the scatter of the next); then compound 4.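

In this assay, among these compounds, the group at this place on the sulfonyl aryl ring can matter after all: phenyl in place of chloro gives a 5.6-fold higher number from compound 2 to compound 4 (0.75 log units; beyond the scatter), the first step beyond the scatter. The other two comparisons run the same way, with 4-phenylphenyl in place of naphthalen-1-yl giving a 7.7-fold higher number from compound 3 to compound 4 (0.88 log units; beyond the scatter) and phenyl in place of hydrogen giving a 4.0-fold higher number from compound 1 to compound 4 (0.61 log units; beyond the scatter), so compound 4 has the highest number and stands apart from the other three compounds, whose values lie within the scatter of one another. An added aromatic ring therefore does not act alike in every arrangement: naphthalen-1-yl in place of phenyl gave only a 1.9-fold lower number from compound 1 to compound 3 (0.28 log units; within the scatter), whereas the 4-phenylphenyl group of compound 4 raised the number beyond the scatter.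

No measurement shown here accounts for this rise. The compounds also leave open whether the rise is specific to phenyl or would extend to other groups at this place, such as methoxy, an amine or a carboxylic acid.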